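A Second Methoxy on Compound 2

The source may hold more compounds than are shown below. What is called first, only, known or untested is meant among the compounds shown, and "the series" means these compounds.

Compound 1 `Oc1cccc(CNc2ncnc3c2ncn3C2CCCCO2)c1`, compound 2 `COc1ccccc1CNc1ncnc2c1ncn2C1CCCCO1` and compound 3 `COc1ccc(CNc2ncnc3c2ncn3C2CCCCO2)c(OC)c1` share one core and differ in the groups on an aromatic ring. In an ADME assay on BJ cells (Homo sapiens) for cytotoxicity, read by MTT assay, with a stated time of 72 h (a higher number here means a weaker inhibitor, a lower number a stronger inhibitor), compound 1 gives > 100000 nM, which is a limit and not a number. In this assay compound 2 gives > 100000 nM, also a limit. In this assay compound 3 gives > 25000 nM, again a limit. Compound 2 therefore has no exact number and stands at the limit of > 100000 nM in this assay, at which 2 of the 3 values shown sit.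

Compound 4 `COc1cccc(OC)c1CNc1ncnc2c1ncn2C1CCCCO1` is compound 2 with one change: methoxy in place of hydrogen on an aromatic carbon. The new methoxy sits ortho to a large group and meta to a methoxy group. The closest measured change, also methoxy in place of hydrogen on an aromatic carbon, is a step that the two limits leave unreadable from compound 2 to compound 3. The other measured change is a step that the two limits leave unreadable from compound 1 to compound 2. Neither gives a size, so no step beyond the scatter is expected in this assay, in either direction.

For compound 4 the estimated value is 80000 nM, with an expected range from 25000 nM to 200000 nM. This estimate means an expected at least 1.2-fold lower number from compound 2 to compound 4 (0.09 log units; that floor lies within the scatter).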

Compound 4, half-maximal inhibitory concentration: > 100000 nM
Compound 4 gave a limit, no number (the forecaster's own chance of this, stated with the estimate: 85%); middle value at least 1.2-fold (0.09 log units) from the limit.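

No step can be read from compound 2 to compound 4, since in this assay each gives only a limit and not a number: the limit of > 100000 nM in this assay, at which 3 of the 4 values shown sit. The compounds shown leave open whether the added methoxy changes the value at all, and in which direction; none of them has an exact number.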